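From 4-butoxyphenyl to 2-chlorophenyl in one antiproliferative test

The compounds below may be only part of what the source reports. "The series", "measured", "known", "first", "only" and "open" are said of these compounds alone.

- compound 1 `O=C(NNc1ccccc1F)c1cccc(NS(=O)(=O)c2cnc(O)nc2O)c1` gives > 20000 nM (a limit)
- compound 2 `O=C(NNc1ccc(F)cc1)c1cccc(NS(=O)(=O)c2cnc(O)nc2O)c1` gives > 20000 nM (a limit)
- compound 3 `CCCCOc1ccc(C(=O)NNC(=O)c2cccc(NS(=O)(=O)c3cnc(O)nc3O)c2)cc1` gives 7370 nM

In a functional assay on SGC-7901 cells (Homo sapiens) for antiproliferative activity, read by MTT assay, with a stated time of 24 h (on this read-out higher numbers stand for weaker inhibition and lower numbers for stronger inhibition), compound 3 gives 7370 nM and is the only one of the three with a number. Compound 1 reports only a limit of the assay, > 20000 nM, not a number. Compound 2 likewise reports only the limit > 20000 nM, not a number. Together these two make up (the limit of > 20000 nM in this assay, at which 2 of the 3 values shown sit).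

Compound 4 `O=C(NNC(=O)c1ccccc1Cl)c1cccc(NS(=O)(=O)c2cnc(O)nc2O)c1` keeps the rest of compound 3 but has 2-chlorophenyl in place of 4-butoxyphenyl on a carbonyl carbon. Among the measured compounds shown here, the one measured step, a step that the two limits leave unreadable from compound 1 to compound 2, lies at another place and offers no size to carry over. For the measured compounds named here, no measured step therefore sizes this change in this assay. Going by the values given here, a loss is still expected rather than a gain, since compound 3 with 7370 nM is the only compound with a readable number, and the other two did not reach one. The expected step is a 1.5-fold higher number from compound 3 to compound 4 (0.17 log units; within the scatter), towards weaker inhibition, and it is only a loose expectation. For compound 4 the estimated value is 11000 nM, with an expected range from 4000 nM to 30000 nM.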

Compound 4, half-maximal inhibitory concentration: 6070 nM
Beside the measured number, compound 4's estimate is 1.8-fold (0.26 log units) above it, and the stated range covers the measured number.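

In this assay, the place on a carbonyl carbon whose other neighbours are an amide-type nitrogen accepts a marked change of group without a readable shift: the step is a 1.2-fold lower number from compound 3 to compound 4 (0.08 log units; within the scatter), so 2-chlorophenyl and 4-butoxyphenyl cannot be told apart here. A readable number therefore no longer rests on compound 3 alone, and it does not depend on the 4-butoxyphenyl group, since compound 4 carries none. Putting (2-chlorophenyl)carbonyl on the amine nitrogen in place of the fluorophenyl groups gives an at least 3.2-fold lower number from compound 2 to compound 4 (0.51 log units; beyond the scatter) and an at least 3.2-fold lower number from compound 1 to compound 4 (0.51 log units; beyond the scatter), both beyond the scatter and both only lower bounds on the true size, as each starts from a limit and not a number: the limit of > 20000 nM in this assay, at which 2 of the 4 values shown sit.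

An unsubstituted phenyl on this carbonyl would show whether the chlorine or the butoxy chain contributes anything at all. Still open, from the compounds shown here alone, is whether a carboxylic acid, an amine or a longer chain at this place would bring the number clearly below those of compound 3 and compound 4.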